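The compounds below may be only part of what the source reports. "The series", "measured", "known", "first", "only" and "open" are said of these compounds alone.

Of the compounds shown here, two that share one core have been measured in a functional assay on NCI-H157 cells (Homo sapiens) for cytotoxicity, read by sulforhodamine B assay; a higher number here means a weaker inhibitor, a lower number a stronger inhibitor. Compound 1 `c1cncc(-c2nnc3sc(-c4ccoc4)nn23)c1` gives 3410 nM in this assay. Compound 2 `Oc1ccc(OCc2nn3c(-c4cccnc4)nnc3s2)cc1` gives 3010 nM in this assay. These two numbers lie within the scatter of each other, so neither compound can be called the stronger inhibitor; compound 2 simply has the lower of the two numbers, by a margin that repeated measurements would not resolve.

Compound 3 `Cc1ccc(OCc2nn3c(-c4cccnc4)nnc3s2)cc1` has not yet been measured. It differs from compound 2 in one place: methyl in place of hydroxy on an aromatic carbon. Among the compounds with values here, no measured pair shows the effect of this change, so nothing in the data points in a direction. The expected step of a 1.2-fold higher number from compound 2 to compound 3 (0.07 log units; within the scatter) is therefore no larger than the scatter, with its direction uncertain. Compound 3 is expected to give 3500 nM in this assay, with a plausible range from 1200 nM to 10000 nM.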

Compound 3, half-maximal inhibitory concentration: 2980 nM
Compound 3: the middle estimate sits 1.2-fold (0.07 log units) above what was measured; the measured number falls inside the stated range.
By their numbers in this assay, from the lowest: compounds 3, 2 and 1 (each within the scatter of the next).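

In this assay, this first pair at this position gives a 1.0-fold lower number from compound 2 to compound 3 (0.00 log units; within the scatter), so the change from 4-hydroxyphenyl to 4-methylphenyl leaves no difference that the measurement can resolve. Hydroxy counts one hydrogen-bond donor and one hydrogen-bond acceptor, and methyl counts neither, yet that difference in counts does not separate compound 2 from compound 3 here. Nothing measured on these compounds offers an explanation for this result.

This is a single pair, so it leaves open whether an amine, a carboxylic acid or a longer chain such as propyl, on that same aromatic carbon, would also stay within the scatter of compound 2. It also leaves open whether methyl in place of hydroxy would read the same way on a different core.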